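Cytotoxicity notes: biphenylmethyl in place of cyclopentylpropyl

The compounds below may be only part of what the source reports. "The series", "measured", "known", "first", "only" and "open" are said of these compounds alone.

Compound 1 `Cc1ccc(-c2c3c(nc(C)c2C(OC(C)(C)C)C(=O)O)CCN(S(C)(=O)=O)C3)cc1` and compound 2 `Cc1ccc(-c2c3c(nc(C)c2C(OC(C)(C)C)C(=O)O)CCN(CCCC2CCCC2)C3)cc1` share one core and differ only at the amine nitrogen in the ring. In an ADME assay on MT2 cells (Homo sapiens) for cytotoxicity, read by XTT assay, with a stated time of 4 days (a lower number here means that less compound is tolerated, a higher number that more compound is tolerated), compound 1 gives > 40000 nM, which is a limit of the assay and not a number. In this assay compound 2 gives > 40000 nM, again a limit of the assay rather than a number. The step that the two limits leave unreadable from compound 1 to compound 2 is therefore not readable in size or direction; what the two values share is the limit of > 40000 nM in this assay, at which 2 of the 2 values shown sit.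

Compound 3 `Cc1ccc(-c2c3c(nc(C)c2C(OC(C)(C)C)C(=O)O)CCN(Cc2ccccc2-c2ccccc2)C3)cc1` has not yet been measured in this assay. Its change from compound 2 is 2-phenylphenyl in place of 2-cyclopentylethyl on a saturated chain carbon bound to an amine nitrogen in a ring. Going by the values given here, the only measured step, a step that the two limits leave unreadable from compound 1 to compound 2, cannot be sized, so no step size can be carried over to this change; the single thing on record is that both measured compounds sit at the limit of > 40000 nM in this assay, at which 2 of the 2 values shown sit. For compound 3 the value in this assay is expected to be 40000 nM, with a range from 15000 nM to 100000 nM. The expected step of a number no higher from compound 2 to compound 3 (the limit leaves the size open) is thus estimated as none beyond the scatter, with a limit rather than a number the likeliest outcome.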

Compound 3, half-maximal cytotoxic concentration: > 40000 nM
Compound 3 ended at the assay's limit (the forecaster's own chance of this, stated with the estimate: 70%); the middle value lies on the limit itself.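

In this assay, going by these compounds alone, compound 3 gives > 40000 nM, a limit of the assay and not a number, so no step from compound 2 to compound 3 can be read. Compounds 1, 2 and 3 share one limit: the limit of > 40000 nM in this assay, at which 3 of the 3 values shown sit.

The compounds shown leave open at what concentration any of them becomes cytotoxic, and whether the substituent on the amine nitrogen in the ring affects that concentration.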